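The source may report more compounds than this note shows. Statements on the series, on what has been measured and on what is new or still open speak of the compounds shown alone.

Measured in an ADME assay on the whole organism for inhibition, with Echinochloa crus-galli var. formosensis as the target, with a stated time of 4 days; on this read-out lower numbers stand for stronger inhibition and higher numbers for weaker inhibition:
compound 1 `CCN(c1nc(Cl)nc(N[C@H](C)c2ccccc2)n1)C(C)C` gives 52500 nM;
compound 2 `CCCNc1nc(Cl)nc(N[C@@H](C)c2ccccc2)n1` gives 15100 nM;
compound 3 `CCNc1nc(Cl)nc(N[C@H](C)c2ccccc2)n1` gives 2690 nM.

Compound 2 thus stands second highest of the three numbers in this assay, beyond the scatter from compound 1 above it and from compound 3 below it. Compound 4 `CCCCNc1nc(Cl)nc(N[C@@H](C)c2ccccc2)n1` differs from compound 2 by methyl in place of hydrogen on a saturated chain carbon, three bonds along the chain from a nitrogen on an aromatic ring. Within the data shown here, the only measured step, a 20-fold lower number from compound 1 to compound 3 (1.29 log units; beyond the scatter), concerns a different change and bears on this one only loosely. Compound 2 and compound 3 show that a longer chain gave a higher number, and a further methyl is expected to continue this modestly, so for compound 4 a step of a 1.7-fold higher number from compound 2 to compound 4 (0.22 log units; within the scatter) is expected. Compound 4 is therefore estimated at 25000 nM, in the range 8000 nM to 80000 nM.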

Compound 4, half-maximal inhibitory concentration: 12900 nM
Estimate against measurement, compound 4: 1.9-fold (0.29 log units) above, and the stated range covers the measured number.
By their numbers in this assay, from the lowest: compound 3; then compounds 4 and 2 (each within the scatter of the next); then compound 1.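

Methyl in place of hydrogen on a saturated chain carbon, three bonds along the chain from a nitrogen on an aromatic ring, gives a 1.2-fold lower number from compound 2 to compound 4 (0.07 log units; within the scatter) in this assay, so the two compounds cannot be told apart there. Among these compounds, this is the first comparison made in a single place on this chain, and from propyl to butyl the added carbon brings no step beyond the scatter. No supporting measurement accounts for this result.

Still open, going by these compounds, is whether a longer chain, such as pentyl, would stay level with butyl. Also open, on these data alone, is what a hydroxyl or an amine at this place would do to the number in this assay.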